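This account rests on a few compounds, and the source may have more. Where it says the series, first, only, none or still open, it means among the compounds named here.

In a functional assay on the whole organism for inhibition, with Cavia porcellus as the target (a higher number here means that more compound is needed for the effect, a lower number that less compound is needed), three compounds have been measured: compound 1 `CCOC(=O)CC(=O)N1CCSC1COc1ccccc1OC` gives 21 mg/kg, compound 2 `COc1ccccc1OCC1SCCN1C(=O)CC(=O)O` gives 20 mg/kg, and compound 3 `COc1ccccc1OCC1N(C(=O)CC(=O)O)CC[S+]1[O-]` gives 20 mg/kg.

Compound 4 `CCOC(=O)CC(=O)N1CC[S+]([O-])C1COc1ccccc1OC` has not yet been measured. Compound 1 differs from compound 2 by one change, (ethyl in place of hydrogen on an oxygen next to a carbonyl group), and this change made a 1.1-fold higher number from compound 2 to compound 1 (0.02 log units; within the scatter). The same change leads from compound 3 to compound 4, (ethyl in place of hydrogen on an oxygen next to a carbonyl group), with the place described in the same words both times. How the core of compound 3 differs from the core of compound 2 is not broken down here; compound 3 stands level with compound 2 at the digits given, and the two share the lowest numbers of the three. For compound 4 the expected step is a 1.1-fold higher number from compound 3 to compound 4 (0.02 log units; within the scatter). This expectation rests on the earlier step, a 1.1-fold higher number from compound 2 to compound 1 (0.02 log units; within the scatter), which lay within the scatter, and on compound 3 giving 20 mg/kg. Compound 4 is therefore estimated at 21 mg/kg in this assay, with a range from 11 mg/kg to 42 mg/kg.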

Compound 4, dose for half-maximal effect: 27 mg/kg
Compound 4: the middle estimate sits 1.3-fold (0.11 log units) below what was measured; low and high end bracket the measured number.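

In this assay, ethyl in place of hydrogen on an oxygen next to a carbonyl group gives a 1.4-fold higher number from compound 3 to compound 4 (0.13 log units; within the scatter). Set beside the earlier step, the change reads alike on the two cores: the same change on two cores in this assay, a 1.1-fold higher number (0.02 log units; within the scatter) from compound 2 to compound 1 and a 1.4-fold higher number (0.13 log units; within the scatter) from compound 3 to compound 4, 1.3-fold (0.11 log units) apart, within the scatter of two such steps. This shows that going from carboxy to ethoxycarbonyl left the number within the scatter on both cores, but two pairs do not show that the same would hold on any further core.

The compounds shown leave open what a longer chain than ethyl on that oxygen would give in this assay. They also leave open what an amine in place of the ethoxy would give.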